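Removing one chloro from compound 1 in this series

The compounds below may be only part of what the source reports. "The series", "measured", "known", "first", "only" and "open" are said of these compounds alone.

The series shares the core shown in compound 1 `CCC1(CCCCN2CCN(c3ccc(Cl)c(Cl)c3)CC2)C(=O)Nc2ccccc21`, which carries a 3,4-dichlorophenyl group at the far end of its side chain. In a functional assay on the whole organism (strain Wistar) with Rattus norvegicus as the target, with a stated time of 5 min (a lower number here means that less compound is needed, a higher number that more compound is needed for the effect), compound 1 gives only a limit, > 20 mg/kg, and not a number. Compound 2 `CCC1(CCCCN2CCC(C)CC2)C(=O)Nc2ccccc21` belongs to the same series, but in this assay compound 2 has "not determined" (no result reported), so it offers no point of comparison. Among the measured compounds shown here, no step between two measured compounds exists here; the single fixed point is the limit of > 20 mg/kg in this assay, at which 1 of the 2 values shown sits.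

Compound 3 `CCC1(CCCCN2CCN(c3ccc(Cl)cc3)CC2)C(=O)Nc2ccccc21` is the next compound to be run in this assay. It differs from compound 1 by hydrogen in place of chloro on an aromatic carbon. The shared core and the rest of the side chain stay untouched. With compound 1 sitting at a limit, no measured step can be read from the numbers shown; a step no larger than the usual scatter is expected, in either direction. Compound 3 is expected near 20 mg/kg, within 6 mg/kg to 40 mg/kg, with a real chance that again only a limit is reported. In this assay the expected step is a number no higher from compound 1 to compound 3 (the limit leaves the size open).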

Compound 3, minimum effective dose: 10 mg/kg
Compound 3: the middle estimate sits 2.0-fold (0.30 log units) above what was measured, and the stated range covers the measured number.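

Going from 3,4-dichlorophenyl to 4-chlorophenyl in this assay gives an at least 2.0-fold lower number from compound 1 to compound 3 (0.30 log units; that floor lies within the scatter), the first step in this series that can be read at all. Compound 1 gives a limit, > 20 mg/kg, and not a number, so this step is only a floor. What is new is that this aromatic carbon accepts hydrogen in place of chloro without the effect being lost in this assay, since compound 3 gives a single number with the shared core and the rest of the side chain unchanged.

The true size of this step cannot be read, nor can any step to compound 2, and the series still has just one reference point on the side of compound 1: the limit of > 20 mg/kg in this assay, at which 1 of the 3 values shown sits. It remains open whether fluoro, methyl or methoxy on this same aromatic carbon would give a number on the same side as hydrogen, and what part the remaining chloro plays, as a compound with an unsubstituted phenyl group is not among those shown.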